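A few compounds are considered here, and "the series" means these few. Any claim that something is new, unique, unknown or untested is made for them only; others in the source may bear on it.

Measured in an in vivo ADME assay on the whole organism (strain 129/SvEvBrd x C57BL/6) for pharmacokinetics, with Mus musculus as the target; on this read-out lower numbers stand for lower oral bioavailability and higher numbers for higher oral bioavailability:
Compound 1 `CC(=O)c1nc([C@@H](O)[C@H](O)[C@H](O)CO)cn1C`: 33.6%
Compound 2 `CC(O)c1nc([C@@H](O)[C@H](O)[C@H](O)CO)c[nH]1`: 22%
Compound 3 `OC[C@@H](O)[C@@H](O)[C@H](O)c1c[nH]c(C(F)(F)C(F)(F)F)n1`: 31%

Compound 2, at 22%, lies within the usual scatter of compound 3, at 31%. Compound 1, at 33.6%, reads higher than compound 2, and this gap goes beyond the scatter.

The next compound to consider is compound 4 `OC[C@@H](O)[C@@H](O)[C@H](O)c1c[nH]c(-c2ncc[nH]2)n1`. Compared with compound 2, it has 1H-imidazol-2-yl in place of 1-hydroxyethyl on an aromatic carbon.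

Among the measured compounds shown here, no two measured compounds differ in only one place, so no measured step can serve as a direct guide to this change. The closest clue is compound 3, which carries another group in that place and gives 31%, a value within the scatter of compound 2. A shift beyond the scatter in this assay is therefore not expected, and no firm direction can be argued. The estimated a number 3 percentage points higher from compound 2 to compound 4 (within the scatter) stays within the scatter. For compound 4, the estimated value is 25%, with an expected range of 12% to 40%.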

Compound 4, oral bioavailability: 28%
The estimate for compound 4 lay 3 percentage points below the measured number, within the range that was stated.
By their numbers in this assay, from the lowest: compounds 2, 4, 3 and 1 (each within the scatter of the next, the first and the last beyond it).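

Among the compounds shown here, this is the first measured step at this position on the aromatic carbon. In this assay, replacing 1-hydroxyethyl with 1H-imidazol-2-yl gives a number 6 percentage points higher from compound 2 to compound 4 (within the scatter), so a group that carries a five-membered aromatic ring can take the place of one with no ring, and oral bioavailability stays within the usual variation between repeat measurements. The two groups have the same count of hydrogen-bond donors and acceptors, and no measurement here explains why the read-out holds steady.

From the compounds shown here alone, what an amine or a carboxylic acid would do in this place remains open, as these groups would change the donor and acceptor counts or add a charge. This single step also leaves open whether the same swap would behave alike on a differently substituted core.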